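Isopropyl to propyl on the enamide chain of two cores

A few compounds are considered here, and "the series" means these few. Any claim that something is new, unique, unknown or untested is made for them only; others in the source may bear on it.

Measured compounds:
Compound 1, `COc1cc2ncnc(N3CCc4ccccc43)c2cc1NC(=O)/C=C/C(C)C`, 6410 nM
Compound 2, `CCC/C=C/C(=O)Nc1cc2c(N3CCc4ccccc43)ncnc2cc1OC`, 2920 nM
Compound 3, `CC(C)/C=C/C(=O)Nc1cc2c(N3CCCc4ccccc43)ncnc2cc1O[C@@H]1CCOC1`, 6820 nM

These three compounds were tested in a functional assay on A549 cells (Homo sapiens) for antiproliferative activity, read by MTT assay, with a stated time of 72 h; on this read-out higher numbers stand for weaker inhibition and lower numbers for stronger inhibition. Compound 1 and compound 2 share one core and differ in a single place: propyl in place of isopropyl on a double-bonded chain carbon bound to a double-bonded chain carbon. That change gave a 2.2-fold lower number from compound 1 to compound 2 (0.34 log units; beyond the scatter). Compound 3 carries a different core; the difference between the two cores is not broken down here. Its number in this assay sits close to that of compound 1, and the two lie within the scatter of each other.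

Compound 4, `CCC/C=C/C(=O)Nc1cc2c(N3CCCc4ccccc43)ncnc2cc1O[C@@H]1CCOC1`, has not yet been measured. It differs from compound 3 by propyl in place of isopropyl on a double-bonded chain carbon bound to a double-bonded chain carbon, the same change that separates compound 1 from compound 2, at the same place. On that basis the step from compound 3 to compound 4 is expected to resemble the earlier one, estimated as a 2.2-fold lower number from compound 3 to compound 4 (0.34 log units; beyond the scatter), because compound 1 to compound 2 gave a 2.2-fold lower number from compound 1 to compound 2 (0.34 log units; beyond the scatter). The number expected for compound 4 in this assay is 3100 nM, with an estimated range from 1500 nM to 6500 nM, resting on a single prior example.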

Compound 4, half-maximal inhibitory concentration: 7320 nM
Compound 4: middle estimate off by 2.4-fold (0.37 log units), on the low side; measured number outside the range, above it.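

In this assay, putting propyl in place of isopropyl on the core of compound 3 gave a 1.1-fold higher number from compound 3 to compound 4 (0.03 log units; within the scatter), so on this core the two chains cannot be told apart. The clear step seen on the core of compound 1 therefore did not show up again here, and a reader cannot count on it carrying over from one core to the other; equally, one step on each core does not establish that the change acts differently on the two, and no reason for either result can be drawn from these compounds. Set side by side, the two steps do not separate, so the series so far gives no firm sign of a dependence on the core: the same change on two cores in this assay, a 2.2-fold lower number (0.34 log units; beyond the scatter) from compound 1 to compound 2 and a 1.1-fold higher number (0.03 log units; within the scatter) from compound 3 to compound 4, 2.4-fold (0.37 log units) apart, within the scatter of two such steps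

The compounds shown leave open how a longer chain such as pentyl, or an amine carried on the same chain, would read on either core. They also leave open which part of the difference between the two cores matters, if any does, and whether the step would hold on a third core.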